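The compounds below may be only part of what the source reports. "The series", "measured", "known", "first", "only" and "open" are said of these compounds alone.

Measured compounds in an ADME assay on CEM-SS cells (Homo sapiens) for cytotoxicity, read by XTT assay, with a stated time of 6 days; on this read-out lower numbers stand for higher toxicity in this test and higher numbers for lower toxicity in this test:
compound 1, `CCCC(=O)OCSc1ccccc1C(=O)NCCCCCNC(C)=O`, 9.2 uM
compound 2, `CCCC(=O)OCSc1ccccc1C(=O)N[C@H]1CCC[C@@H]1C(N)=O`, 31.2 uM; 43.3 uM (2 entries)

Compound 1 is the only compound here with a single number in this assay; compound 2 contributes several entries instead, which sit close together, as shown by the several entries of compound 2 in this assay, 31.2 uM; 43.3 uM (2 entries). Taken on their own, the two readings show compound 1 at 9.2 uM and compound 2 at 31.2 uM; 43.3 uM (2 entries), and nothing further is claimed about the pair, since no step between them has been worked out.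

The piece follows the change from compound 1 to compound 3, `CCCC(=O)OCSc1ccccc1C(=O)NCC(=O)NCC(=O)OC`. The change is ((methoxycarbonyl)methyl)carbamoyl in place of 4-acetamidobutyl on a saturated chain carbon bound to an amide-type nitrogen. The shared core and its ester side chain stay as they are; only the group on the amide-type nitrogen is exchanged.

Among the compounds with values here, no measured step of this kind is available, so the expectation rests on compound 1 alone. A step in this assay from compound 1 to compound 3 of a 1.6-fold higher number from compound 1 to compound 3 (0.21 log units; within the scatter) is expected, that is, a move no larger than the usual scatter, if any, toward lower toxicity. Compound 3 is therefore estimated at 15 uM, with a range from 5 uM to 45 uM.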

Compound 3, half-maximal toxic concentration: > 100 uM
Compound 3: no number, only a limit; the forecaster's own chance of this, stated with the estimate: 10%; at least 6.6-fold (0.82 log units) between middle value and limit.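

In this assay, putting ((methoxycarbonyl)methyl)carbamoyl in place of 4-acetamidobutyl on a saturated chain carbon bound to an amide-type nitrogen gives an at least 10-fold higher number from compound 1 to compound 3 (1.03 log units; beyond the scatter), the first step available here, and it shows that with the shared core and its ester side chain unchanged, the group at this place alone can carry the reading beyond the scatter toward lower toxicity in this test. The two groups have the same number of heavy atoms, no ring and no net charge, and the entering group differs in holding more oxygen, one more double bond and more hydrogen-bond acceptors, so the step arises without any change in heavy-atom count. Compound 3 gives only a limit, not a number: the limit of > 100 uM in this assay, at which 1 of the 3 values shown sits.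

From the compounds shown here alone, what stays open is how far the step really reaches, and which part of the entering group goes with it, the carbamoyl or the methyl ester. A carboxylic acid in place of the methyl ester, or a plain longer alkyl chain without a carbonyl, would begin to separate these parts.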